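The source may report more compounds than this note shows. Statements on the series, on what has been measured and on what is new or still open speak of the compounds shown alone.

Measured so far:
- compound 1 `CC(=O)OCC(CCn1cc(C#Cc2cc(F)cc(F)c2)c(=O)n(C(=O)c2ccccc2)c1=O)COC(C)=O` — a functional assay on HeLa cells (Homo sapiens) for antiproliferative activity, read by MTT assay, with a stated time of 72 h; a higher number here means a weaker inhibitor, a lower number a stronger inhibitor: 64500 nM
- compound 2 `CC(=O)OCC(CCn1cc(C#Cc2ccc(Br)cc2)c(=O)n(C(=O)c2ccccc2)c1=O)COC(C)=O` — this assay: 47200 nM
- compound 3 `CCCCCCCCC#Cc1cn(CCC(COC(C)=O)COC(C)=O)c(=O)n(C(=O)c2ccccc2)c1=O` — this assay: 32400 nM

Compound 3 carries the lowest of the three numbers, yet neither gap separates it from the others: a 2.0-fold lower number from compound 1 to compound 3 (0.30 log units; within the scatter) and a 1.5-fold lower number from compound 2 to compound 3 (0.16 log units; within the scatter). The remaining step, a 1.4-fold lower number from compound 1 to compound 2 (0.14 log units; within the scatter), is likewise within the scatter. On these three compounds the group on the triple-bonded carbon, whether 3,5-difluorophenyl, 4-bromophenyl or octyl, leaves the read-out essentially flat.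

Compound 4 `CC(=O)OCC(CCn1cc(C#CCCCCl)c(=O)n(C(=O)c2ccccc2)c1=O)COC(C)=O` differs from compound 3 by chloro in place of pentyl on a saturated chain carbon, three bonds along the chain from a triple-bonded carbon. Among the measured compounds shown here, no measured pair makes this kind of change; all three measured steps exchange the whole group on the triple-bonded carbon rather than altering one carbon within the chain. They bear on it only indirectly, in that each of them stays within the scatter, which gives no ground to expect a change beyond it here. For compound 4 in this assay the expected value is therefore 35000 nM, with a range of 12000 nM to 95000 nM. This estimate amounts to a 1.1-fold higher number from compound 3 to compound 4 (0.03 log units; within the scatter), a step that is expected to remain within the scatter in either direction.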

Compound 4, half-maximal inhibitory concentration: 52800 nM
Estimate against measurement, compound 4: 1.5-fold (0.18 log units) below; the range from low to high includes it.
By their numbers in this assay, from the lowest: compounds 3, 2, 4 and 1 (each within the scatter of the next).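

In this assay, among the compounds shown here, chloro in place of pentyl on a saturated chain carbon, three bonds along the chain from a triple-bonded carbon, gives a 1.6-fold higher number from compound 3 to compound 4 (0.21 log units; within the scatter) and is the first change made within the chain rather than by exchanging the whole group, yet the read-out stays flat. The 3-chloropropyl group also stays level with both aryl groups, with a 1.1-fold higher number from compound 2 to compound 4 (0.05 log units; within the scatter) and a 1.2-fold lower number from compound 1 to compound 4 (0.09 log units; within the scatter), so the four compounds now form a single band in which octyl, 3-chloropropyl, 4-bromophenyl and 3,5-difluorophenyl cannot be told apart. No measurement shown here offers an explanation for this flatness.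

As far as these compounds go, whether the read-out stays flat with an amine, a hydroxyl or a carboxylic acid in place of the chloro, or with a longer chain such as decyl, remains open. From the compounds shown here alone, all four compounds also share the rest of the core of compound 1, so the response to a change outside the group on the triple-bonded carbon remains unknown.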